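The source may hold more compounds than are shown below. What is called first, only, known or untested is meant among the compounds shown, and "the series" means these compounds.

Compound 1, `N=C(N)NS(=O)(=O)c1ccc(N/C(S)=N\c2ccnc3cc(C(F)(F)F)ccc23)cc1`, is one of two measured members of this set; in a functional assay on HT-1080 cells (Homo sapiens) for antiproliferative activity, read by sulforhodamine B assay, with a stated time of 48 h (a lower number here means a stronger inhibitor, a higher number a weaker inhibitor), compound 1 gives 24300 nM. Compound 2, `O=S(=O)(Nc1ccccn1)c1ccc(N/C(S)=N\c2ccnc3cc(C(F)(F)F)ccc23)cc1`, carries a pyridin-2-yl on the sulfonamide nitrogen instead of the open-chain group of compound 1, and compound 2 gives 28000 nM, a change of a 1.2-fold higher number from compound 1 to compound 2 (0.06 log units; within the scatter), so compound 2 and compound 1 stand within the scatter of each other. Compound 3, `Cc1cc(C)nc(NS(=O)(=O)c2ccc(N/C(S)=N\c3ccnc4cc(C(F)(F)F)ccc34)cc2)n1`, differs from compound 2 by 4,6-dimethylpyrimidin-2-yl in place of pyridin-2-yl on a sulfonamide nitrogen. Among the compounds with values here, only one measured step bears on this change: the swap of the group on the sulfonamide nitrogen from compound 1 to compound 2, which stayed within the scatter. Compound 3 is therefore expected to show a step of a 1.0-fold lower number from compound 2 to compound 3 (0.02 log units; within the scatter) in this assay, with no shift beyond the scatter. The estimate for compound 3 is 27000 nM, with a range from 10000 nM to 75000 nM.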

Compound 3, half-maximal inhibitory concentration: 29500 nM
Beside the measured number, compound 3's estimate is 1.1-fold (0.04 log units) below it; the measured number falls inside the stated range.
By their numbers in this assay, from the lowest: compounds 1, 2 and 3 (each within the scatter of the next).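

The step from pyridin-2-yl to 4,6-dimethylpyrimidin-2-yl on a sulfonamide nitrogen, read in this assay, is small (a 1.1-fold higher number from compound 2 to compound 3 (0.02 log units; within the scatter)), and the step from the open-chain group stays small as well (a 1.2-fold higher number from compound 1 to compound 3 (0.08 log units; within the scatter)). The three groups on this nitrogen thus stand within the scatter of each other, and the set now spans a wider range of groups than the first pair did, adding a ring with more hetero atoms and two methyl groups. No evidence is at hand on why these groups read alike.

The compounds shown leave open whether a carboxylic acid, a short amine chain or plain hydrogen on this nitrogen would stay within the same scatter. Going by these compounds, all three share the rest of the core, so the effect of exchanging trifluoromethyl for chlorine also remains open.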